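This account rests on a few compounds, and the source may have more. Where it says the series, first, only, none or still open, it means among the compounds named here.

Series notes. Compound 1 `O=C(CN1CCN(c2ccccc2F)CC1)Nc1ccc(C(=O)/C=C/c2cn(Cc3ccc(Br)cc3)nn2)cc1` gives 11300 nM in a functional assay on MCF7 cells (Homo sapiens) for inhibition, read by MTT assay; a lower number here means a stronger inhibitor, a higher number a weaker inhibitor. Compound 2 `COc1ccccc1N1CCN(CC(=O)Nc2ccc(C(=O)/C=C/c3cn(Cc4ccc(Br)cc4)nn3)cc2)CC1` differs by methoxy in place of fluoro on an aromatic carbon and gives 36800 nM; the step is a 3.3-fold higher number from compound 1 to compound 2 (0.51 log units; beyond the scatter). Compound 3 `CCCCCCCCCCn1cc(/C=C/C(=O)c2ccc(NC(=O)CN3CCN(c4ccccc4F)CC3)cc2)nn1` differs from compound 1 by nonyl in place of 4-bromophenyl on a saturated chain carbon bound to an aromatic nitrogen; compound 3 gives 40400 nM, a step of a 3.6-fold higher number from compound 1 to compound 3 (0.55 log units; beyond the scatter). Compound 4 `CCCCCCCCCCn1cc(/C=C/C(=O)c2ccc(NC(=O)CN3CCN(c4ccccc4OC)CC3)cc2)nn1` awaits measurement in this assay; it differs from compound 3 by methoxy in place of fluoro on an aromatic carbon, the same change already seen from compound 1 to compound 2, at the same place. The expectation for compound 4 rests on that single prior step, a 3.3-fold higher number from compound 1 to compound 2 (0.51 log units; beyond the scatter), applied to compound 3 and its value 40400 nM. Among the compounds with values here, compound 4 is therefore expected to show a step of about a 3.0-fold higher number from compound 3 to compound 4 (0.47 log units; beyond the scatter), with only one precedent behind it. Compound 4 is estimated at 120000 nM, between 45000 nM and 320000 nM.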

Compound 4, half-maximal inhibitory concentration: 44800 nM
Compound 4: middle estimate off by 2.7-fold (0.43 log units), on the high side; the whole stated range lies above it.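

In this assay, the change from 2-fluorophenyl to 2-methoxyphenyl does not carry over from the core of compound 1 to the core of compound 3, the new step being a 1.1-fold higher number from compound 3 to compound 4 (0.04 log units; within the scatter): the same change on two cores in this assay, a 3.3-fold higher number (0.51 log units; beyond the scatter) from compound 1 to compound 2 and a 1.1-fold higher number (0.04 log units; within the scatter) from compound 3 to compound 4, 2.9-fold (0.47 log units) apart, beyond the scatter of two such steps

Nonyl in place of 4-bromophenyl does not carry over either, the new step being a 1.2-fold higher number from compound 2 to compound 4 (0.09 log units; within the scatter): the same change on two cores in this assay, a 3.6-fold higher number (0.55 log units; beyond the scatter) from compound 1 to compound 3 and a 1.2-fold higher number (0.09 log units; within the scatter) from compound 2 to compound 4, 2.9-fold (0.47 log units) apart, beyond the scatter of two such steps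

The two changes therefore do not add up across these four compounds, but this single set of four gives no cause for that and does not show how either change behaves on any other core.

As far as these compounds go, whether a hydroxyl or a chloro in place of the methoxy would follow the 4-bromophenyl or the nonyl pattern stays open. So does the effect of a shorter chain in place of nonyl.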